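The source may hold more compounds than are shown below. What is called first, only, known or untested is meant among the compounds shown, and "the series" means these compounds.

Of the compounds shown here, three have so far been measured in a functional assay on HCT-116 cells (Homo sapiens) for cytotoxicity, read by MTT assay, with a stated time of 48 h; a lower number here means a stronger inhibitor, a higher number a weaker inhibitor. Compound 1 `COc1cc(/C=C/C(=O)C2=C(/C=C/c3ccc(O)c(OC)c3)NC(=O)NC2c2ccccc2)ccc1O` gives 25000 nM in this assay. Compound 2 `COc1cc(/C=C/C(=O)C2=C(/C=C/c3ccc(O)c(OC)c3)NC(=O)NC2c2ccc(C)cc2)ccc1O` differs from compound 1 by methyl in place of hydrogen on an aromatic carbon, and in this assay compound 2 gives 12500 nM; the step of a 2.0-fold lower number from compound 1 to compound 2 (0.30 log units; within the scatter) is small. Compound 3 `COc1cc(/C=C/C(=O)C2=C(/C=C/c3ccc(O)c(OC)c3)NC(=S)NC2c2ccccc2)ccc1O` has a different core from compound 1, and the difference between the two cores is not broken down here. In this assay compound 3 gives 100000 nM, the highest number of the three, with both compound 1 and compound 2 standing beyond the scatter below it.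

Compound 4 `COc1cc(/C=C/C(=O)C2=C(/C=C/c3ccc(O)c(OC)c3)NC(=S)NC2c2ccc(C)cc2)ccc1O` has not yet been measured. Among the measured compounds shown here, it stands to compound 3 as compound 2 stands to compound 1: the change is methyl in place of hydrogen on an aromatic carbon, the same change at the same place as the one between compound 1 and compound 2. For the measured compounds named here, the only guide to its effect is that single earlier step, which stayed within the scatter. For compound 4 the expected step is a 2.0-fold lower number from compound 3 to compound 4 (0.30 log units; within the scatter), an expectation that rests on the earlier step of a 2.0-fold lower number from compound 1 to compound 2 (0.30 log units; within the scatter) being small. The number for compound 4 in this assay is therefore estimated at 50000 nM, with the expected range running from 20000 nM to 150000 nM.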

Compound 4, half-maximal inhibitory concentration: 50000 nM
Beside the measured number, compound 4's estimate shows no gap at the digits printed, and the stated range covers the measured number.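

Carried to a second core, the change from phenyl to 4-methylphenyl gives a 2.0-fold lower number from compound 3 to compound 4 (0.30 log units; within the scatter) in this assay. Set beside the same change on the first core, this step shows no difference between the two cores: the same change on two cores in this assay, a 2.0-fold lower number (0.30 log units; within the scatter) from compound 1 to compound 2 and a 2.0-fold lower number (0.30 log units; within the scatter) from compound 3 to compound 4, 1.0-fold (0.00 log units) apart, within the scatter of two such steps In this one pair of cores, then, the methyl group can be carried from one core to the other with a step of the same size, but both steps lie within the scatter, so the agreement is one between two small steps; it does not show that the methyl group has a real effect on either core, and it does not show that the match would hold on any further core.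

The compounds shown leave open whether a different group at the same place on the aromatic ring, such as a chlorine atom, an amine, a carboxylic acid or a longer chain such as propyl, would give a step beyond the scatter on either core. They also leave open whether a larger step of that kind would carry from one core to the other as closely as this small one does, which is the stricter test of whether the two cores respond alike.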